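Trading the amide of compound 2 for a phenyl urea

The source may report more compounds than this note shows. Statements on the series, on what has been measured and on what is new or still open speak of the compounds shown alone.

Three measured compounds share one core and are scored in an ADME assay on MT4 cells (Homo sapiens) for cytotoxicity, read by MTT assay; a higher number here means that more compound is tolerated, a lower number that less compound is tolerated. Compound 1 `Cc1nc(NC(=O)NC2CCCCC2)c(C)c(C(OC(C)(C)C)C(=O)O)c1-c1ccc2c(c1C)CCCO2` gives 11000 nM. Compound 3 `Cc1nc(NC(=O)NC2CCCCC2)c(C)c(C(OC(C)(C)C)C(=O)O)c1-c1ccc(C(F)(F)F)cc1` gives 9800 nM. Compound 2 `Cc1ccc(-c2c(C)nc(C(=O)N(C)Cc3ccccc3)c(C)c2C(OC(C)(C)C)C(=O)O)cc1C` gives 77000 nM, the highest of the three numbers, beyond the scatter from compound 1 and from compound 3. Among the measured compounds shown here, the only one-place step that has been measured, a 1.1-fold lower number from compound 1 to compound 3 (0.05 log units; within the scatter), swaps the aryl group on the core and leaves the tolerated concentration essentially unchanged.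

Compound 4 `Cc1ccc(-c2c(C)nc(NC(=O)Nc3ccccc3)c(C)c2C(OC(C)(C)C)C(=O)O)cc1C` is the new compound. Its difference from compound 2 is (phenylcarbamoyl)amino in place of benzyl(methyl)carbamoyl on an aromatic carbon. For the measured compounds named here, no measured step covers this change directly, because compound 1 and compound 3 both carry a urea and compound 2 carries an amide while the aryl group also differs. Still, compound 1 and compound 3, the two urea-bearing compounds, sit well below compound 2 in this assay, and the aryl swap between them mattered little. The expectation is therefore that moving to a urea in compound 4 lowers the tolerated concentration, by roughly a 3.9-fold lower number from compound 2 to compound 4 (0.59 log units; beyond the scatter). For compound 4 the estimated value in this assay is 20000 nM, with a likely range from 7000 nM to 60000 nM.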

Compound 4, half-maximal cytotoxic concentration: 9900 nM
Beside the measured number, compound 4's estimate is 2.0-fold (0.31 log units) above it; measured number inside the range.
By their numbers in this assay, from the lowest: compounds 3, 4 and 1 (each within the scatter of the next); then compound 2.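

In this assay, the exchange of benzyl(methyl)carbamoyl for (phenylcarbamoyl)amino gives a 7.8-fold lower number from compound 2 to compound 4 (0.89 log units; beyond the scatter). Among the compounds shown here, the one earlier step changed the aryl group and stayed within the scatter, whereas this one shows that the group on the aromatic carbon next to the ring nitrogen can shift the tolerated concentration while the 3,4-dimethylphenyl group stays the same. The entering group carries hydrogen-bond donors and the leaving group carries none, but the two groups also differ in how they are joined to the shared core, and nothing measured here explains the step.

Going by these compounds, it remains open which part of the exchange accounts for the lower number: a benzyl urea or a urea with a methylated nitrogen would separate the phenyl group from the urea link, while a plain amine at this position would show how much of either group is needed at all. On these data alone, it is also open whether the step keeps its size when the 3,4-dimethylphenyl group gives way to another aryl group, such as the trifluoromethyl-bearing one of compound 3.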